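The compounds below may be only part of what the source reports. "The series", "measured", "known", "first", "only" and "open" are said of these compounds alone.

Compound 1 `FC(F)(F)c1ccc2c(c1)nc(-c1cccnc1)n2C1CC1`: > 10000 nM.
Compound 2 `Fc1ccc2nc(-c3cccnc3)[nH]c2c1`: > 10000 nM.

Both readings come from an assay on V79 cells for inhibition of cytochrome P450 11B2, mitochondrial (Homo sapiens), read by HTRF, with a stated time of 1 h; a lower number here means a stronger inhibitor, a higher number a weaker inhibitor. For compound 2 the figure is a limit of the assay, not a number. The figure for compound 1 is likewise a limit, so that (the limit of > 10000 nM in this assay, at which 2 of the 2 values shown sit). For the measured compounds named here, compound 2 thus stands at the edge of what the assay reports, and no measured step between two compounds is available to show how a change on the aromatic nitrogen moves the reading.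

Compound 3 `Fc1ccc2nc(-c3cccnc3)n(C3CCC3)c2c1` differs from compound 2 in one place: cyclobutyl in place of hydrogen on an aromatic nitrogen. With the two measured values both sitting at the limit, the expected step that the limit leaves unreadable from compound 2 to compound 3 is none beyond the scatter. Compound 3 is expected to return a limit again rather than a number. The estimate for compound 3 is 15000 nM, with a range from 4000 nM to 60000 nM.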

Compound 3, half-maximal inhibitory concentration: > 5000 nM
Compound 3: only a limit was reported (the forecaster's own chance of this, stated with the estimate: 80%); the middle value lies beyond the limit too.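

Compound 2 gives > 10000 nM in this assay, which is a limit and not a number. Compound 3 gives > 5000 nM, again a limit. No step can be read between compound 2 and compound 3. From the compounds shown here alone, whether cyclobutyl in place of hydrogen on an aromatic nitrogen changes the reading at all stays open.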